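From phenyl to 4-chlorophenyl on compound 3

This account rests on a few compounds, and the source may have more. Where it says the series, first, only, none or still open, it means among the compounds named here.

Compound 3 (`O=C1NCCN1c1ccc(S(=O)(=O)Nc2ccccc2)cc1`) gives 470 nM in a functional assay on MCF7 cells (Homo sapiens) for antiproliferative activity, read by sulforhodamine B assay, with a stated time of 48 h (on this read-out higher numbers stand for weaker inhibition and lower numbers for stronger inhibition), and stands close to compound 1 (`CCCCc1ccc(NS(=O)(=O)c2ccc(N3CCNC3=O)cc2)cc1`) at 770 nM in the same test, while compound 2 (`Cc1ccc(NS(=O)(=O)c2ccc(N3CCNC3=O)cc2)cc1C`) lies lower at 230 nM by a modest gap. Compound 4 (`O=C1NCCN1c1ccc(S(=O)(=O)Nc2ccc(Cl)cc2)cc1`) has chloro in place of hydrogen on an aromatic carbon, para to a large group (chloro in place of hydrogen on an aromatic carbon). Two measured steps change groups on that same phenyl (a 1.6-fold lower number from compound 1 to compound 3 (0.21 log units; within the scatter) and a 2.0-fold higher number from compound 2 to compound 3 (0.31 log units; beyond the scatter)). Going by the values given here, one lies within the scatter, the other is modest, and no measured compound carries chloro. A small step is therefore expected, leaning slightly toward a lower number and staying within the scatter (a 1.2-fold lower number from compound 3 to compound 4 (0.09 log units; within the scatter)). For compound 4 the estimate is 380 nM (expected range 160 nM to 850 nM).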

Compound 4, half-maximal inhibitory concentration: 170 nM
Beside the measured number, compound 4's estimate is 2.2-fold (0.35 log units) above it, within the range that was stated.
By their numbers in this assay, from the lowest: compounds 4 and 2 (each within the scatter of the next); then compounds 3 and 1 (each within the scatter of the next).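

In this assay, chloro on the aromatic carbon para to a large group gives a 2.8-fold lower number from compound 3 to compound 4 (0.44 log units; beyond the scatter), so this carbon responds to a single added atom, whereas butyl and hydrogen here stay within the scatter of each other. Chloro also separates clearly from butyl at this carbon, with a 4.5-fold lower number from compound 1 to compound 4 (0.66 log units; beyond the scatter). One chloro does about as well as the two methyl groups of the 3,4-dimethylphenyl, with a 1.4-fold lower number from compound 2 to compound 4 (0.13 log units; within the scatter).

Nothing available explains why chloro acts this way. Going by these compounds, whether fluoro, methoxy or an amine on this same carbon would also lower the number remains open.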